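Swapping methyl for chloro on the shared core

A few compounds are considered here, and "the series" means these few. Any claim that something is new, unique, unknown or untested is made for them only; others in the source may bear on it.

Compound 1 `CCn1c(/C=C2/C(=O)Nc3ccc(C)cc32)nc2ccccc21` belongs to a small set of related compounds tested in a functional assay on A549 cells (Homo sapiens) for cytotoxicity, read by MTT assay, with a stated time of 48 h; a higher number here means a weaker inhibitor, a lower number a stronger inhibitor. In this assay compound 1 gives > 50000 nM, which is a limit of the assay rather than a number. Compound 2 `Cn1c(/C=C2/C(=O)Nc3ccc([N+](=O)[O-])cc32)nc2ccccc21` also gives only a limit, > 50000 nM. For the measured compounds named here, compound 3 `CC(C)n1c(/C=C2/C(=O)Nc3ccc(Br)cc32)nc2ccccc21` is the one member with a measured number, 8630 nM. So compound 1 sits at the limit, as does compound 2, which is where two of the three values gather (the limit of > 50000 nM in this assay, at which 2 of the 3 values shown sit).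

Compound 4 `CCn1c(/C=C2/C(=O)Nc3ccc(Cl)cc32)nc2ccccc21` has not been measured. It differs from compound 1 in one place: chloro in place of methyl on an aromatic carbon. Going by the values given here, no measured pair in the set shows this same exchange, so the size of the step can only be guessed. Because compound 3 reaches a measured number of 8630 nM, a measured number is expected for compound 4 as well, though the difference in the group on the other nitrogen leaves this uncertain. The expected step is an at least 2.5-fold lower number from compound 1 to compound 4 (0.39 log units; beyond the scatter), toward a stronger inhibitor. For compound 4 the estimated value in this assay is 20000 nM, with a plausible range from 6000 nM to 70000 nM, and a real chance that only a limit is reported.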

Compound 4, half-maximal inhibitory concentration: > 50000 nM
Compound 4: only a limit was reported; the forecaster's own chance of this, stated with the estimate: 45%; middle value at least 2.5-fold (0.39 log units) away from the limit.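

In this assay, compound 1 and compound 4 each give only a limit, so no step can be read between them: the limit of > 50000 nM in this assay, at which 3 of the 4 values shown sit. The compounds shown leave open whether chloro in place of methyl on an aromatic carbon changes the inhibitory strength of this shared core at all, and by how much.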